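Sulfonyl aryl swap: nitrile out, methoxy in

A few compounds are considered here, and "the series" means these few. Any claim that something is new, unique, unknown or untested is made for them only; others in the source may bear on it.

Compound 1 `Cc1cc(C)cc(S(=O)(=O)c2cnc3ccc(C)cc3c2N2CCC(C)CC2)c1` gives 80% in an assay on isolated protein for displacement of a labelled ligand from metabotropic glutamate receptor 5 (Homo sapiens), with a stated time of 60 min, tested at 1 uM; a higher number here means more inhibition at the concentration tested (going by the name of the read-out), a lower number less inhibition. Compound 2 `Cc1ccc2ncc(S(=O)(=O)c3ccc(C#N)cc3)c(N3CCC(C)CC3)c2c1` gives 55% in this assay, the lower of the two numbers, reached through a number 25 percentage points lower from compound 1 to compound 2 (beyond the scatter). Compound 3 `COc1cccc(S(=O)(=O)c2cnc3ccc(C)cc3c2N2CCC(C)CC2)c1` carries the change (3-methoxyphenyl in place of 4-cyanophenyl on a sulfonyl sulfur). Among the compounds with values here, the only measured step bearing on this place is the one where a number 25 percentage points lower from compound 1 to compound 2 (beyond the scatter) on replacing a plain aryl by the nitrile-bearing one, so taking the nitrile away again is expected to recover much of that ground, with an expected step of a number 15 percentage points higher from compound 2 to compound 3 (beyond the scatter). The estimate for compound 3 is 70%, with a range from 55% to 85%.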

Compound 3, a percentage reported as inhibition, at one concentration (the size of the read-out at that concentration, not a potency): 96%
For compound 3 the middle estimate is 26 percentage points below the measured one; the whole stated range lies below it.
By their numbers in this assay, from the lowest: compound 2; then compound 1; then compound 3.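

Working from the sulfonyl aryl, 3-methoxyphenyl in place of 4-cyanophenyl brings a number 41 percentage points higher from compound 2 to compound 3 (beyond the scatter) and 3-methoxyphenyl in place of 3,5-dimethylphenyl brings a number 16 percentage points higher from compound 1 to compound 3 (beyond the scatter) so the change does more than return to the level of compound 1. This position on the sulfonyl sulfur therefore still had room above the value of the dimethyl-bearing aryl. Nothing here accounts for the higher number of compound 3.

As far as these compounds go, whether the methoxy group itself matters, or only the loss of the nitrile, stays open. So does how an amine, a carboxylic acid or a longer alkoxy chain would read on this aryl.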